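Chloro on the benzyl ring: compound 2 to compound 3

This account rests on a few compounds, and the source may have more. Where it says the series, first, only, none or still open, it means among the compounds named here.

Measured so far:
compound 1 `Clc1ccccc1Cn1nnc2c(NC3CCCC3)ncnc21` — 21 nM
compound 2 `Nc1ccc(CNc2ncnc3c2nnn3Cc2ccccc2)cc1` — 9500 nM

In an assay on cell membranes for binding affinity to adenosine receptor A1 (Bos taurus), read by radioligand binding (a lower number here means a stronger inhibitor, a higher number a weaker inhibitor), compound 2 gives 9500 nM, the highest of the two numbers in hand. Compound 1 gives 21 nM, a far lower number, but the two compounds differ in more than one place, so their values can only be set side by side, not read as a single step.

Compound 3 `Nc1ccc(CNc2ncnc3c2nnn3Cc2ccccc2Cl)cc1` is not yet measured. It differs from compound 2 in one place: chloro in place of hydrogen on an aromatic carbon. The chloro enters on the benzyl ring, ortho to a large group, so that compound 3 carries the same 2-chlorobenzyl group as compound 1 while keeping the 4-aminobenzylamine of compound 2.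

Among the measured compounds shown here, no step between measured compounds matches this change. For the measured compounds named here, a modest move to a lower number in this assay is expected, since compound 1, the only compound carrying the 2-chlorobenzyl, gives 21 nM, though that comparison is confounded by the other difference. The step from compound 2 to compound 3 is estimated at a 2.7-fold lower number from compound 2 to compound 3 (0.43 log units; beyond the scatter). For compound 3 the expected value is 3500 nM, in the range 1000 nM to 12000 nM.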

Compound 3, inhibition constant: > 1000 nM
Compound 3 was reported as a limit; the forecaster's own chance of this, stated with the estimate: 5%; the middle value lies beyond the limit too.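

In this assay compound 3 gives > 1000 nM, which is a limit of the assay and not a number. The effect of chloro in place of hydrogen on the benzyl ring, going from compound 2, cannot be read, because the reading for compound 3 stops at that limit: the limit of > 1000 nM in this assay, at which 1 of the 3 values shown sits.

The other single change can be read: with the 2-chlorobenzyl held constant, 4-aminobenzyl in place of cyclopentyl on a nitrogen on an aromatic ring gives an at least 47-fold higher number from compound 1 to compound 3 (1.67 log units; beyond the scatter), a large step beyond the scatter, so the 2-chlorobenzyl alone does not keep the number low, a point the two earlier compounds could not separate because they differ in more than one place.

Still open, from the compounds shown here alone, is what chloro does on the benzyl ring when cyclopentyl sits on that nitrogen, where readings could fall clear of the limit. Also open, going by these compounds, is whether the loss follows the benzyl group as a whole or its amine, which a plain benzyl, a 4-hydroxybenzyl or a 4-carboxybenzyl on that nitrogen would help to separate.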